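This account rests on a few compounds, and the source may have more. Where it says the series, first, only, none or still open, it means among the compounds named here.

Measured so far in a functional assay on HeLa cells (Homo sapiens) for inhibition, read by sulforhodamine B assay, with a stated time of 48 h; on this read-out higher numbers stand for weaker inhibition of growth and lower numbers for stronger inhibition of growth:
compound 1 `COC(=O)[C@@]1(C)CCC=C2[C@@H]1CC[C@@H](C)[C@]2(C)Cc1c[nH]c2ccccc12` gives 3600 nM
compound 2 `COC(=O)[C@@]1(C)CCC=C2[C@@H]1CC[C@@H](C)[C@]2(C)Cc1c[nH]c2c(C)cccc12` gives 4900 nM
compound 3 `COC(=O)[C@@]1(C)CC[C@@H]2C3=C1CC[C@@H](C)[C@]3(C)Cc1c2[nH]c2ccccc12` gives 3200 nM

Compound 1 and compound 3 carry different cores; the difference between the two cores is not broken down here, and their two values lie within the scatter of each other.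

Compound 2 differs from compound 1 by methyl in place of hydrogen on an aromatic carbon and the step is a 1.4-fold higher number from compound 1 to compound 2 (0.13 log units; within the scatter). Compound 4 `COC(=O)[C@@]1(C)CC[C@@H]2C3=C1CC[C@@H](C)[C@]3(C)Cc1c2[nH]c2c(C)cccc12`, not yet measured, carries the same kind of change on the core of compound 3: methyl in place of hydrogen on an aromatic carbon. The surroundings are not identical: in compound 2 the aromatic ring is part of a fused or bridged system of two rings, in compound 4 of five rings.

The expectation for compound 4 rests on compound 3 with 3200 nM and on the step of a 1.4-fold higher number from compound 1 to compound 2 (0.13 log units; within the scatter). The step expected from compound 3 to compound 4 in this assay is a 1.4-fold higher number from compound 3 to compound 4 (0.15 log units; within the scatter), placed beside that earlier step. Compound 4 is estimated at 4500 nM, with a range from 2500 nM to 8500 nM.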

Compound 4, concentration for 50% growth inhibition: 12000 nM
Beside the measured number, compound 4's estimate is 2.7-fold (0.43 log units) below it; the whole stated range lies below it.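

In this assay, methyl in place of hydrogen on an aromatic carbon gives a 3.8-fold higher number from compound 3 to compound 4 (0.57 log units; beyond the scatter). The size of the step does not carry over unchanged from one core to the other: the same change on two cores in this assay, a 1.4-fold higher number (0.13 log units; within the scatter) from compound 1 to compound 2 and a 3.8-fold higher number (0.57 log units; beyond the scatter) from compound 3 to compound 4, 2.8-fold (0.44 log units) apart, beyond the scatter of two such steps This rests on a single pair of steps with one group at one place, so it shows that the size of this step differs between these two cores, but not why it differs or whether other changes would differ in the same way.

The compounds shown leave open how a methoxy group or an amine at the same place would behave on either core. Also open, going by these compounds, is what a carboxylic acid or an amide in place of the methyl ester would do on these cores.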